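From pyridin-4-yl to quinolin-3-yl on the shared core

A few compounds are considered here, and "the series" means these few. Any claim that something is new, unique, unknown or untested is made for them only; others in the source may bear on it.

Compound 1 `CCOC(=O)c1cnc(-c2ccccc2)nc1NN1C(=O)C=C(C)C1=O` gives 100 nM in a functional assay on Jurkat cells for inhibition of nuclear factor NF-kappa-B complex (Homo sapiens); on this read-out lower numbers stand for stronger inhibition and higher numbers for weaker inhibition.
Compound 2 `CCOC(=O)c1cnc(-c2cccs2)nc1NN1C(=O)C=C(C)C1=O` gives 20 nM in this assay.
Compound 3 `CCOC(=O)c1cnc(-c2ccncc2)nc1NN1C(=O)C=C(C)C1=O` gives 6000 nM in this assay.

Compound 3 stands with the highest number of the three, and both steps towards it were large: a 60-fold higher number from compound 1 to compound 3 (1.78 log units; beyond the scatter) and a 300-fold higher number from compound 2 to compound 3 (2.48 log units; beyond the scatter). The change from compound 3 to compound 4 `CCOC(=O)c1cnc(-c2cnc3ccccc3c2)nc1NN1C(=O)C=C(C)C1=O` is quinolin-3-yl in place of pyridin-4-yl on an aromatic carbon. Among the measured compounds shown here, no measured step involves quinolin-3-yl, so the two steps to compound 3 are the only guide: each of them shows that pyridin-4-yl went with the weakest inhibition here, whereas a ring of carbon only, as in compound 1, or thiophen-2-yl, as in compound 2, went with much lower numbers. Since compound 4 removes pyridin-4-yl and brings in a group that contains a six-membered ring of carbon only, a lower number than that of compound 3 is expected in this assay, though how far it drops is uncertain. The step from compound 3 to compound 4 is therefore estimated as a 10-fold lower number from compound 3 to compound 4 (1.00 log units; beyond the scatter). For compound 4 the expected value is 600 nM, within a range from 60 nM to 6000 nM.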

Compound 4, half-maximal inhibitory concentration: 6000 nM
For compound 4 the middle estimate is 10-fold (1.00 log units) below the measured one; the range from low to high includes it.
By their numbers in this assay, from the lowest: compound 2; then compound 1; then compounds 3 and 4 (each within the scatter of the next).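

In this assay, quinolin-3-yl brings a six-membered aromatic ring of carbon only in addition to a ring with one hetero atom, yet the read-out stays put, with no change at the digits printed from compound 3 to compound 4 (within the scatter); a ring of carbon only within the group therefore did not restore the lower numbers here. Phenyl and thiophen-2-yl still stand well apart from quinolin-3-yl, with a 60-fold higher number from compound 1 to compound 4 (1.78 log units; beyond the scatter) and a 300-fold higher number from compound 2 to compound 4 (2.48 log units; beyond the scatter). Among these four compounds, both groups holding a ring nitrogen go with the high numbers and none goes against this, though two such groups are a thin basis.

Nothing at hand explains why the numbers fall this way. Going by these compounds, whether the ring nitrogen itself matters stays open, and naphthalen-2-yl, with rings of carbon only, or pyridin-2-yl, with its nitrogen placed differently, would bear on that question.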